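The source may report more compounds than this note shows. Statements on the series, on what has been measured and on what is new or still open speak of the compounds shown alone.

In a functional assay on Jurkat cells (Homo sapiens) for cytotoxicity, read by luminescence and CellTiter-Glo, with a stated time of 3 days (on this read-out lower numbers stand for stronger inhibition and higher numbers for weaker inhibition), compound 1 (`O=C(Nc1ccc(C(F)(F)F)cc1)c1cc(Cl)ccc1O`) gives 710 nM as its value and sits within the scatter of both measured neighbours. Compound 2 (`O=C(Nc1ccc(C(F)(F)F)cc1)c1cc(Cl)c(-c2ccccc2)cc1O`) gives 1160 nM as its value, and compound 3 (`O=C(Nc1ccc(C(F)(F)F)cc1)c1cc(Br)ccc1O`) gives 620 nM as its value. Phenyl in place of hydrogen on an aromatic carbon accounts for a 1.6-fold higher number from compound 1 to compound 2 (0.21 log units; within the scatter) and bromo in place of chloro on an aromatic carbon accounts for a 1.1-fold lower number from compound 1 to compound 3 (0.06 log units; within the scatter) in these notes.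

Compound 4 (`O=C(Nc1ccc(C(F)(F)F)c(Cl)c1)c1cc(Cl)ccc1O`) has not yet been measured. Its difference from compound 1 is chloro in place of hydrogen on an aromatic carbon with the chloro on an aromatic carbon of a six-membered aromatic ring of carbon only, ortho to a trifluoromethyl group and meta to a large group. Neither measured step changes the ring carrying the trifluoromethyl group, so both bear on this change only indirectly. The closest guide is the halogen exchange, a 1.1-fold lower number from compound 1 to compound 3 (0.06 log units; within the scatter) as noted, while the addition of phenyl gave a 1.6-fold higher number from compound 1 to compound 2 (0.21 log units; within the scatter) and also stayed small. No step beyond the scatter is therefore expected in this assay and no firm direction can be assigned. The expected step is a 1.2-fold lower number from compound 1 to compound 4 (0.07 log units; within the scatter) on this estimate. The estimate for compound 4 is 600 nM with an expected range from 250 nM to 1400 nM on the same read-out.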

Compound 4, half-maximal inhibitory concentration: 690 nM
Compound 4: the middle estimate sits 1.2-fold (0.06 log units) below what was measured; measured number inside the range.
By their numbers in this assay, from the lowest: compounds 3, 4, 1 and 2 (each within the scatter of the next).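

Among the compounds shown here, a new chloro, ortho to a trifluoromethyl group and meta to a large group, is the first change at this position, and in this assay it stays within the scatter (a 1.0-fold lower number from compound 1 to compound 4 (0.01 log units; within the scatter)). The earlier steps were made elsewhere on the shared core, so this result adds that a single chloro at this position also leaves the cytotoxicity read-out of compound 1 without a step beyond the scatter, and among the four compounds shown, none goes against this. No measurement at hand offers an explanation for this result.

For the compounds shown here, whether this holds for other groups at the same position remains open, as an amine, a carboxylic acid or a longer chain could give a quite different number from the single chloro of compound 4. Also open, going by these compounds, is whether the chloro of compound 4 behaves the same way when combined with the bromo of compound 3 or the phenyl of compound 2, since each change is seen here only on its own.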